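The compounds below may be only part of what the source reports. "The series", "measured", "known", "first", "only" and "open" are said of these compounds alone.

Working notes on the series, read in an ADME assay on HEL cells (Homo sapiens) for cytotoxicity, with a stated time of 3 days; on this read-out lower numbers stand for higher toxicity in this test and higher numbers for lower toxicity in this test. Compound 1 (`Cc1cc(-c2cccc(O)c2)c2ncc(CSCCc3ccccc3)n2c1`) gives 11.4 ug/mL and compound 2 (`Cc1cc(-c2cccc([N+](=O)[O-])c2)cn2c(CSCCc3ccccc3)cnc12`) gives 43 ug/mL. Compound 2 therefore holds the higher of the two numbers, with a gap beyond the usual scatter. Within the data shown here, the two compounds differ in more than one place, so the series offers no measured single-change step.

Compound 3 (`Cc1cc(-c2ccccc2O)cn2c(CSCCc3ccccc3)cnc12`) has not yet been measured and differs from compound 2 by one change: 2-hydroxyphenyl in place of 3-nitrophenyl on an aromatic carbon. In words, this is 2-hydroxyphenyl in place of 3-nitrophenyl on an aromatic carbon.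

Among the measured compounds shown here, the only guide to the direction is compound 1, which also carries a hydroxyphenyl group and gives 11.4 ug/mL. That is a single comparison with a differently built compound, so the expectation is loose. The expected move is a 2.4-fold lower number from compound 2 to compound 3 (0.38 log units; beyond the scatter), toward a lower number and so higher toxicity in this test, with a size modestly beyond the scatter. For compound 3 the estimated value is 18 ug/mL, with an expected range of 6 ug/mL to 55 ug/mL.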

Compound 3, half-maximal cytotoxic concentration: > 50 ug/mL
Compound 3 ended at the assay's limit; the forecaster's own chance of this, stated with the estimate: 10%; at least 2.7-fold (0.44 log units) between middle value and limit.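

In this assay, among these compounds, 2-hydroxyphenyl in place of 3-nitrophenyl on this aromatic carbon, two atoms from the ring nitrogen, gives the first single-change step: an at least 1.1-fold higher number from compound 2 to compound 3 (0.06 log units; that floor lies within the scatter). The result for compound 3 is a limit of the assay and not a number: the limit of > 50 ug/mL in this assay, at which 1 of the 3 values shown sits. The step therefore shows that the 3-nitrophenyl group is not required at this position for a high number in this test, as 2-hydroxyphenyl also reaches the limit, but the printed floor lies within the scatter and does not establish a real rise.

The compounds shown leave open how an unsubstituted phenyl, an aminophenyl or a carboxyphenyl group would read on this same aromatic carbon, and so whether the hydroxyl group of 2-hydroxyphenyl plays any part in the result. They also leave open how far the true value of compound 3 lies past its limit, so the step from the 3-nitrophenyl compound has a floor but no measured size.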